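The source may hold more compounds than are shown below. What is called first, only, known or untested is meant among the compounds shown, and "the series" means these compounds.

Compound 1 `Nc1nc2c(c(-c3ccco3)cn2[C@@H]2O[C@H](CO)[C@@H](O)[C@H]2O)c(=O)[nH]1` and compound 2 `Nc1nc2c(c(-c3cc4ccccc4o3)cn2[C@@H]2O[C@H](CO)[C@@H](O)[C@H]2O)c(=O)[nH]1` share one core, and compound 3 `CNc1ncnc2c1c(-c1cc3ccccc3o1)cn2[C@@H]1O[C@H](CO)[C@@H](O)[C@H]1O` and the not yet measured compound 4 `CNc1ncnc2c1c(-c1ccco1)cn2[C@@H]1O[C@H](CO)[C@@H](O)[C@H]1O` share another; the difference between the two cores is not broken down here. In a functional assay on HL-60 cells (Homo sapiens) for antiproliferative activity, read by XTT assay, with a stated time of 72 h (on this read-out lower numbers stand for stronger inhibition and higher numbers for weaker inhibition), compound 1 gives > 20000 nM, which is a limit of the assay and not a number. In this assay compound 2 gives > 20000 nM, again a limit. Between them lies (furan-2-yl in place of 1-benzofuran-2-yl on an aromatic carbon), and the step that the two limits leave unreadable from compound 2 to compound 1 therefore cannot be read, because both values sit at the limit of > 20000 nM in this assay, at which 2 of the 3 values shown sit. In this assay, within the data shown here, compound 3 gives 8950 nM, the only true number among the three. The same change, (furan-2-yl in place of 1-benzofuran-2-yl on an aromatic carbon), leads from compound 3 to compound 4, with the place described identically. The measured pair leaves the size of this change open, so the expectation for compound 4 rests mainly on the value of compound 3 at 8950 nM. The step from compound 3 to compound 4 is expected to be a 1.7-fold higher number from compound 3 to compound 4 (0.22 log units; within the scatter). Compound 4 is thus estimated at 15000 nM in this assay, within 5000 nM to 40000 nM.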

Compound 4, half-maximal inhibitory concentration: 620 nM
Estimate against measurement, compound 4: 24-fold (1.38 log units) above, outside the stated range (below it).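

In this assay, putting furan-2-yl in place of 1-benzofuran-2-yl on the aromatic carbon gives a 14-fold lower number from compound 3 to compound 4 (1.16 log units; beyond the scatter), so on this core the change clearly goes with stronger inhibition. On the other core, the same change cannot be read, because compound 1 and compound 2 both give a limit of the assay and not a number: the limit of > 20000 nM in this assay, at which 2 of the 4 values shown sit. The effect is therefore seen on one core only, which shows that the change can matter a great deal there but does not show whether it carries over to the other core, where it could be equally large, smaller or absent.

As far as these compounds go, what a thiophen-2-yl or a plain phenyl group, or an amine, would do on the same aromatic carbon stays open, so it is unclear whether furan-2-yl itself matters or merely the loss of the six-membered aromatic ring. Also open, from the compounds shown here alone, is which part of the difference between the two cores separates compound 4 from compound 1.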